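Swapping 3-fluorophenyl for pyridin-3-yl

The compounds below may be only part of what the source reports. "The series", "measured", "known", "first", "only" and "open" are said of these compounds alone.

Compound 1 `COc1ccc(S(=O)(=O)N2CCc3cccc(-c4ccc(F)cc4)c32)cc1`: 79 nM
Compound 2 `COc1ccc(S(=O)(=O)N2CCc3cccc(-c4cccc(F)c4)c32)cc1`: 84.7 nM

In a functional assay on MKN-45 cells (Homo sapiens) for inhibition, with a stated time of 72 h (on this read-out lower numbers stand for stronger inhibition and higher numbers for weaker inhibition), compound 2 gives 84.7 nM and compound 1 gives 79 nM, so the two cannot be told apart. The measured step between them is a 1.1-fold higher number from compound 1 to compound 2 (0.03 log units; within the scatter). For the measured compounds named here, compound 2 therefore stands level with the only other measured compound.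

Compound 3 `COc1ccc(S(=O)(=O)N2CCc3cccc(-c4cccnc4)c32)cc1` has not yet been measured. It carries pyridin-3-yl in place of 3-fluorophenyl on an aromatic carbon.

Going by the values given here, only one measured step bears on this change, and it bears only loosely. That step, a 1.1-fold higher number from compound 1 to compound 2 (0.03 log units; within the scatter), exchanges 4-fluorophenyl for 3-fluorophenyl, so it shows that this site tolerated one small change. It does not test a ring with a hetero atom, so the data give no direction for compound 3, and a wide range is needed. With no sign of a large shift, the expected change in this assay is modest: a 1.2-fold lower number from compound 2 to compound 3 (0.08 log units; within the scatter).

For compound 3 the estimated value is 70 nM, with an expected range from 20 nM to 250 nM.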

Compound 3, half-maximal inhibitory concentration: 68.5 nM
The estimate for compound 3 lay 1.0-fold (0.01 log units) above the measured number; the range from low to high includes it.
By their numbers in this assay, from the lowest: compounds 3, 1 and 2 (each within the scatter of the next).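

In this assay, the new compound gives two steps: a 1.2-fold lower number from compound 2 to compound 3 (0.09 log units; within the scatter) and a 1.2-fold lower number from compound 1 to compound 3 (0.06 log units; within the scatter), and both stay within the usual scatter. The earlier pair only moved a fluorine around a ring of carbon, whereas this change removes the fluorine and brings in pyridin-3-yl, a ring with a nitrogen as its hetero atom and a hydrogen-bond acceptor, and the read-out still cannot tell the compounds apart. This position on the shared core therefore accepts a ring with a hetero atom as well as a fluorinated ring of carbon, with no measurable gain or loss in these cells, and nothing available explains why the number holds.

As far as these compounds go, all three compounds carry a six-membered aromatic ring at this carbon, so it remains open whether the position would accept something quite different, such as a morpholine ring, a simple amine, a carboxylic acid or a longer alkyl chain. It is also open whether the nitrogen's place in the ring matters, since pyridin-2-yl and pyridin-4-yl are not among the compounds shown.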